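From trifluoropropyl to pentafluorobutyl: compound 2 to compound 3

The compounds below may be only part of what the source reports. "The series", "measured", "known", "first", "only" and "open" are said of these compounds alone.

Of the compounds shown here, two have been read so far, compound 1 (`[O-][S+](CCC(F)(F)C(F)(F)F)c1nc(-c2ccccc2)c(-c2ccccc2)[nH]1`) and compound 2 (`O=S(=O)(CCC(F)(F)F)c1nc(-c2ccccc2)c(-c2ccccc2)[nH]1`). In a functional assay on the whole organism with Rattus norvegicus as the target (a lower number here means that less compound is needed, a higher number that more compound is needed for the effect), compound 1 gives > 75 mg/kg, which is a limit of the assay and not a number. In this assay compound 2 gives > 75 mg/kg, again a limit and not a number. Compound 2 thus has no numerical position, and the record so far is the limit of > 75 mg/kg in this assay, at which 2 of the 2 values shown sit.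

Next comes compound 3 (`O=S(=O)(CCC(F)(F)C(F)(F)F)c1nc(-c2ccccc2)c(-c2ccccc2)[nH]1`). Its difference from compound 2 is trifluoromethyl in place of fluoro on a saturated chain carbon bound to two fluorine atoms and a saturated chain carbon, which turns 3,3,3-trifluoropropyl into 3,3,4,4,4-pentafluorobutyl.

Within the data shown here, no measured step gives a size for this change. No shift beyond the scatter is expected in this assay, in either direction, and another limit is the likeliest reading. This expectation rests on compound 2, whose > 75 mg/kg is a limit. The estimated change is a number no higher from compound 2 to compound 3 (the limit leaves the size open). Compound 3 is expected to read 75 mg/kg, with an estimated range from 25 mg/kg to 200 mg/kg.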

Compound 3, dose for half-maximal effect: > 75 mg/kg
Compound 3 was reported as a limit (the forecaster's own chance of this, stated with the estimate: 65%); the middle value lies on the limit itself.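

In this assay compound 3 gives > 75 mg/kg, a limit of the assay and not a number. Compound 2 also stands at a limit, so no step can be read between compound 2 and compound 3. Left open is what size, if any, the change from 3,3,3-trifluoropropyl to 3,3,4,4,4-pentafluorobutyl has in this assay.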